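Swapping a chlorophenyl amide for a saturated bicyclic group

This account rests on a few compounds, and the source may have more. Where it says the series, first, only, none or still open, it means among the compounds named here.

Three compounds share a core in which an amide carbonyl on a small nitrogen ring carries a group that varies, while the other side of the ring bears an aromatic ring. Compound 1 `O=C(C1CCC2(CCC2)CC1)N1CC(c2nc(-c3cccc(Cl)c3)no2)C1`, compound 2 `O=C(c1ccc(Cl)cc1)N1CC(c2nc(-c3cccc(F)c3)no2)C1` and compound 3 `Cc1cccc(-c2noc(C3CN(C(=O)C4CCC(F)(F)CC4)C3)n2)c1` were tested in an assay on HEK293 cells for positive allosteric modulation of metabotropic glutamate receptor 5 (Homo sapiens), read by FLIPR; a higher number here means that more compound is needed for the effect, a lower number that less compound is needed. Compound 1 gives 1100 nM, compound 2 gives 2500 nM and compound 3 gives 590 nM. Compound 2 therefore stands at the highest number of the three, needing the most compound for the effect, and its distance from both others lies beyond the usual scatter. The two lower numbers belong to the compounds whose carbonyl carries a saturated ring rather than an aromatic one.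

Compound 4 `O=C([C@@H]1CC2CCC1C2)N1CC(c2nc(-c3cccc(F)c3)no2)C1` has not yet been measured. It differs from compound 2 in one place: a group of 7 heavy atoms (7 carbon; 2 five-membered non-aromatic rings of carbon only) in place of a group of 7 heavy atoms (6 carbon, 1 chlorine; one six-membered aromatic ring of carbon only), on a carbonyl carbon. With this change compound 4 moves toward the pattern of compound 1 and compound 3, both of which carry a saturated ring on the carbonyl and give lower numbers than compound 2. The expectation is a step downward from compound 2 to compound 4 of a 3.1-fold lower number from compound 2 to compound 4 (0.49 log units; beyond the scatter) in this assay, beyond the scatter. Compound 4 is estimated at 800 nM, with a range from 300 nM to 2500 nM.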

Compound 4, half-maximal effective concentration: 100 nM
Compound 4: middle estimate off by 8.0-fold (0.90 log units), on the high side, and the stated range ends above it.
By their numbers in this assay, from the lowest: compound 4; then compounds 3 and 1 (each within the scatter of the next); then compound 2.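

In this assay, replacing the 4-chlorophenyl on a carbonyl carbon with a saturated group of two five-membered carbon rings gives a 25-fold lower number from compound 2 to compound 4 (1.40 log units; beyond the scatter), a large step. The earlier compounds shown here differed from one another in more than one place, so they could not isolate this position, whereas here the rest of the molecule stays the same and the whole step belongs to this one exchange. Both groups have the same heavy-atom count and neither has hydrogen-bond donors, hydrogen-bond acceptors or a net charge, so those counts do not distinguish them, and no supporting measurement is available to explain the size of the step.

The compounds shown do not separate the loss of the chlorine from the loss of the aromatic ring, a question that a plain phenyl or a cyclohexyl on the same carbonyl carbon could help to settle. As far as these compounds go, it also remains open how much the defined stereocentre matters, which the opposite mirror-image form of the saturated group would test.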